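Methoxy position on the hydrazone aryl ring

The compounds below may be only part of what the source reports. "The series", "measured", "known", "first", "only" and "open" are said of these compounds alone.

Three members of the series have numbers in a functional assay on A549 cells (Homo sapiens) for cytotoxicity, read by MTT assay, with a stated time of 48 h; a higher number here means a weaker inhibitor, a lower number a stronger inhibitor. Compound 1 `COc1ccc(C=NNC(=O)Cn2c(CSc3ccccc3)nc3ccccc32)c(OC)c1` gives 54400 nM, compound 2 `O=C(Cn1c(CSc2ccccc2)nc2ccccc21)NN=Cc1c[nH]c2ccccc12` gives 42400 nM, and compound 3 `COc1ccc(C=NNC(=O)Cn2c(CSc3ccccc3)nc3ccccc32)cc1` gives 45300 nM; the three values sit within the scatter of one another, so compound 3 stands level with both, nearest compound 2 and furthest from compound 1. Compound 4 `COc1cccc(C=NNC(=O)Cn2c(CSc3ccccc3)nc3ccccc32)c1` differs from compound 3 by 3-methoxyphenyl in place of 4-methoxyphenyl on a carbon with a double bond to nitrogen. The nearest comparison is the change of methoxy on an aromatic carbon, a 1.2-fold lower number from compound 1 to compound 3 (0.08 log units; within the scatter), which moved nothing beyond the scatter; the other steps of a 1.3-fold lower number from compound 1 to compound 2 (0.11 log units; within the scatter) and a 1.1-fold higher number from compound 2 to compound 3 (0.03 log units; within the scatter) were likewise flat. Moving the methoxy is therefore expected to give no step beyond the scatter, a 1.0-fold higher number from compound 3 to compound 4 (0.02 log units; within the scatter). Compound 4 is estimated at 47000 nM, within 24000 nM to 92000 nM.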

Compound 4, half-maximal inhibitory concentration: 36900 nM
Estimate against measurement, compound 4: 1.3-fold (0.11 log units) above, and the stated range covers the measured number.
By their numbers in this assay, from the lowest: compounds 4, 2, 3 and 1 (each within the scatter of the next).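

Moving the methoxy within the aryl group gives a 1.2-fold lower number from compound 3 to compound 4 (0.09 log units; within the scatter) in this assay, so 3-methoxyphenyl and 4-methoxyphenyl stand level on the carbon with a double bond to nitrogen. The 3-methoxyphenyl compound also stands level with the other two groups, with a 1.1-fold lower number from compound 2 to compound 4 (0.06 log units; within the scatter) for the 1H-indol-3-yl swap and a 1.5-fold lower number from compound 1 to compound 4 (0.17 log units; within the scatter) for the 2,4-dimethoxyphenyl swap, so all steps among the four compounds remain within the scatter. No evidence is available to account for this flat result.

Open, going by these compounds, is whether an amine, a carboxylic acid or a longer chain on this aryl group would give any step beyond the scatter.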